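The compounds below may be only part of what the source reports. "The series", "measured", "known", "first", "only" and "open" are said of these compounds alone.

Compound 3 `Cc1nc(-c2ccsc2)sc1COc1ccc2c(c1)OCC2CC(=O)O` stands highest of the three measured compounds in a functional assay on CHO cells for agonist activity at Free fatty acid receptor 1 (Homo sapiens), read by FLIPR and calcium flux, tested at 100 nM (on this read-out lower numbers stand for a weaker effect and higher numbers for a stronger effect at the one concentration tested), at 56.5%. Compound 2 `Cc1nc(-c2cccs2)sc1COc1ccc2c(c1)OCC2CC(=O)O` gives 35.2%, and compound 1 `Cc1nc(-c2ccccc2)oc1COc1ccc2c(c1)OCC2CC(=O)O` gives 7.15%. Going by the values given here, the one single-point step on record, a number 21.3 percentage points higher from compound 2 to compound 3 (beyond the scatter), shows that swapping the aromatic ring on that carbon moves the read-out by a modest amount. Compound 4 `Cc1nc(-c2cccc3ccccc23)sc1COc1ccc2c(c1)OCC2CC(=O)O` takes the next such swap: naphthalen-1-yl in place of thiophen-3-yl on an aromatic carbon. Among the compounds with values here, no measured step covers a bicyclic ring at this position, so the direction is open; on the size of the step from compound 2 to compound 3, a change within a modest range is expected in this assay, and the estimated step is a number 8.5 percentage points lower from compound 3 to compound 4 (within the scatter). For compound 4 the estimate is 48%, expected between 18% and 78%.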

Compound 4, a percentage reported as activity, at one concentration (the size of the read-out at that concentration, not a potency): 8.53%
Compound 4: middle estimate off by 39.5 percentage points, on the high side; measured number below the stated range.
By their numbers in this assay, from the lowest: compounds 1 and 4 (each within the scatter of the next); then compound 2; then compound 3.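

Replacing a thiophene with naphthalen-1-yl on this aromatic carbon gives a number 48 percentage points lower from compound 3 to compound 4 (beyond the scatter) and a number 26.7 percentage points lower from compound 2 to compound 4 (beyond the scatter), so both thiophene isomers stand above the bicyclic group. The position therefore responds to more than the thiophene attachment point, and a change here can cost most of the read-out. No measurement on hand explains the drop.

The compounds shown do not separate the number of rings from the loss of the ring sulfur or the attachment point on naphthalene. Naphthalen-2-yl or pyridin-3-yl on the same carbon remains open.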